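Benzothiazole amide-nitrogen variation: urea to ester

A few compounds are considered here, and "the series" means these few. Any claim that something is new, unique, unknown or untested is made for them only; others in the source may bear on it.

Measured compounds:
- compound 1, `COc1ncc(-c2ccc3nc(NC(=O)NCCN4CCCC4)sc3c2)cc1NS(=O)(=O)c1ccc(F)cc1`: 310 nM
- compound 2, `CNC(=O)Nc1nc2ccc(-c3cnc(OC)c(NS(=O)(=O)c4ccc(F)cc4)c3)cc2s1`: 870 nM

Among the compounds with values here, compound 2 stands as the higher of the two numbers in a functional assay on HCT-116 cells (Homo sapiens) for antiproliferative activity, read by MTT assay, with a stated time of 72 h; a higher number here means a weaker inhibitor, a lower number a stronger inhibitor; its nearest neighbour is compound 1, reached by the only step on record, a 2.8-fold higher number from compound 1 to compound 2 (0.45 log units; beyond the scatter).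

Compound 3, `CCOC(=O)CNc1nc2ccc(-c3cnc(OC)c(NS(=O)(=O)c4ccc(F)cc4)c3)cc2s1`, has not been measured. It differs from compound 2 by (ethoxycarbonyl)methyl in place of methylcarbamoyl on a nitrogen on an aromatic ring. Within the data shown here, the one measured step, from compound 1 to compound 2, concerns a different part of the molecule, the saturated chain carbon bound to the amide-type nitrogen, and so does not bear on this change directly; it only shows that alterations around the amide-type nitrogen of this core can shift this assay by a modest amount beyond the scatter. Among the measured compounds shown here, no measured pair tells how an (ethoxycarbonyl)methyl group on the ring nitrogen compares with methylcarbamoyl. The expectation is therefore a modest step of uncertain direction, with some lean towards a higher number; compound 3 is expected to give 1800 nM, within 500 nM to 7000 nM, corresponding to an expected 2.1-fold higher number from compound 2 to compound 3 (0.32 log units; beyond the scatter).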

Compound 3, half-maximal inhibitory concentration: > 20000 nM
Compound 3 gave a limit, no number; the forecaster's own chance of this, stated with the estimate: 10%; middle value at least 11-fold (1.04 log units) away from the limit.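

In this assay compound 3 gives a limit of the assay and not a number: the limit of > 20000 nM in this assay, at which 1 of the 3 values shown sits. Even so, the step can be read in one direction: putting (ethoxycarbonyl)methyl in place of methylcarbamoyl on the nitrogen on the aromatic ring gives an at least 22-fold higher number from compound 2 to compound 3 (1.36 log units; beyond the scatter), a large step, whereas the earlier change within the carbamoyl chain gave only a modest one, a 2.8-fold higher number from compound 1 to compound 2 (0.45 log units; beyond the scatter). Within the data shown here, measured against the compound with the (2-(pyrrolidin-1-yl)ethyl)carbamoyl group the distance is larger still, an at least 64-fold higher number from compound 1 to compound 3 (1.80 log units; beyond the scatter), so both carbamoyl compounds give measurable values in this assay while the one compound without a carbamoyl group on this nitrogen reaches the limit.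

The compounds shown leave open which part of the change carries the step, since the carbonyl moves one atom further out, the amide-type nitrogen leaves and the ethyl ester enters all at once. A carboxylic acid in place of the ethyl ester, an N-methyl acetamide on the same methylene, or a plain acetyl group on the ring-bound nitrogen would each separate these parts.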